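A Methyl for the Hydroxy on Compound 3

The source may hold more compounds than are shown below. What is called first, only, known or untested is meant among the compounds shown, and "the series" means these compounds.

Among the three measured compounds, compound 3 `Cn1c(-c2ccc(O)cc2)nc2c(NC3CCCC3)ncnc21` gives the lowest number, 521 nM in an assay on CHO cells for displacement of a labelled ligand from adenosine receptor A3 (Homo sapiens), read by scintillation counting, with a stated time of 3 h; a higher number here means a weaker inhibitor, a lower number a stronger inhibitor. Compound 1 `COc1ccc(-c2nc3c(NC4CCCC4)ncnc3n2C)cc1` gives 1850 nM, and compound 2 `Cn1c(-c2ccc(C(=O)O)cc2)nc2c(NC3CCCC3)ncnc21` gives 25700 nM. Compound 4 `Cc1ccc(-c2nc3c(NC4CCCC4)ncnc3n2C)cc1` differs from compound 3 by methyl in place of hydroxy on an aromatic carbon. For the measured compounds named here, no measured pair matches this change exactly. The nearest guides are a 3.6-fold lower number from compound 1 to compound 3 (0.55 log units; beyond the scatter) and a 49-fold lower number from compound 2 to compound 3 (1.69 log units; beyond the scatter), which both show the hydroxy giving the strongest binding of the three groups tried. Removing it for a methyl, which brings 0 hydrogen-bond donors and 0 hydrogen-bond acceptors, is therefore expected to raise the number, more in line with the methoxy case than the carboxy case. Compound 4 is estimated at 2000 nM, within 600 nM to 7000 nM. The expected step reads a 3.8-fold higher number from compound 3 to compound 4 (0.58 log units; beyond the scatter).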

Compound 4, inhibition constant: 480 nM
The estimate for compound 4 lay 4.2-fold (0.62 log units) above the measured number, outside the stated range (below it).
By their numbers in this assay, from the lowest: compounds 4 and 3 (each within the scatter of the next); then compound 1; then compound 2.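

In this assay, a 1.1-fold lower number from compound 3 to compound 4 (0.04 log units; within the scatter) shows that at this place on the ring, hydroxy can give way to methyl without a change beyond the scatter, so the hydroxy is not required for binding at this level. Methyl also separates from the other two groups, with a 3.9-fold lower number from compound 1 to compound 4 (0.59 log units; beyond the scatter) and a 54-fold lower number from compound 2 to compound 4 (1.73 log units; beyond the scatter) as the steps, so the higher numbers of compound 1 and compound 2 do not follow simply from losing the hydroxy. Nothing available explains this result. From the compounds shown here alone, whether an amine, a chlorine or a longer chain such as ethyl would be tolerated here remains open.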